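Moving the Methyl Around the Benzyl Ring

This account rests on a few compounds, and the source may have more. Where it says the series, first, only, none or still open, it means among the compounds named here.

The study measures hydroxamic acids in an assay on isolated protein for inhibition of protein deacetylase HDAC6 (Homo sapiens), read by fluorescence, with a stated time of 1 h, tested at 100 nM; on this read-out lower numbers stand for less inhibition and higher numbers for more inhibition at the one concentration tested (going by the name of the read-out). Compound 1 `O=C(/C=C/c1ccc(OCc2nc(C3CCN(Cc4ccccc4)CC3)no2)cc1)NO` carries an unsubstituted benzyl group on the piperidine nitrogen, and in this assay compound 1 gives 71%. Compound 2 `Cc1ccccc1CN1CCC(c2noc(COc3ccc(/C=C/C(=O)NO)cc3)n2)CC1` differs from it by a methyl in place of hydrogen on an aromatic carbon, and in this assay compound 2 gives 68%. The step of a number 3 percentage points lower from compound 1 to compound 2 (within the scatter) is within the scatter, so the two numbers cannot be told apart. Compound 2 has the lower of the two numbers shown, but its nearest neighbour, compound 1, lies within the scatter of it.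

Compound 3 `Cc1cccc(CN2CCC(c3noc(COc4ccc(/C=C/C(=O)NO)cc4)n3)CC2)c1` is the next member. Its difference from compound 2 is 3-methylphenyl in place of 2-methylphenyl on a saturated chain carbon bound to an amine nitrogen in a ring. For the measured compounds named here, the only step measured so far concerns adding the methyl, not moving it, and that step a number 3 percentage points lower from compound 1 to compound 2 (within the scatter) did not leave the scatter. Going by the values given here, no measured pair shows what shifting the methyl from one aromatic carbon to another does. The expectation for compound 3 is therefore a step of no change at the digits printed from compound 2 to compound 3 (within the scatter) of no size beyond the scatter. Compound 3 is thus estimated at 68%, within 55% to 80%.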

Compound 3, a percentage reported as inhibition, at one concentration (the size of the read-out at that concentration, not a potency): 73%
Beside the measured number, compound 3's estimate is 5 percentage points below it; measured number inside the range.
By their numbers in this assay, from the lowest: compounds 2, 1 and 3 (each within the scatter of the next).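

In this assay, for the compounds shown here, shifting the methyl from 2-methylphenyl to 3-methylphenyl on a saturated chain carbon bound to an amine nitrogen in a ring gives a number 5 percentage points higher from compound 2 to compound 3 (within the scatter) and is the first measured move of this group from one aromatic carbon to another, so the move cannot be told from no effect on this read-out. Read against the unsubstituted benzyl group, the 3-methylbenzyl compound gives a number 2 percentage points higher from compound 1 to compound 3 (within the scatter), which means that the methyl now stands within the scatter of the unsubstituted ring on both of the aromatic carbons tested, where the earlier pair had covered only one of them. The data offer nothing that bears on why these numbers lie so close together.

The compounds shown leave open whether 4-methylphenyl at the same place would also stay within the scatter, and what a chlorine atom, a methoxy group or a carboxylic acid on this ring would do. Going by these compounds, a percentage at one concentration is not a potency, so whether compound 1, compound 2 and compound 3 differ in potency also remains open.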